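The compounds below may be only part of what the source reports. "The series", "measured", "known", "first", "only" and "open" are said of these compounds alone.

Compounds measured so far:
compound 1 `O=C(Nc1ccc2[nH]ncc2c1)[C@H]1CCCN1C(=O)C1(c2cccc(Cl)c2)CCCC1` — 5.4
compound 2 `O=C(Nc1ccc2[nH]ccc2n1)[C@H]1CCCN1C(=O)C1(c2cccc(Cl)c2)CCCC1` — 5.9

In a physicochemical assay for lipophilicity, at pH 7.4 (a lower number here means a more polar compound, a higher number a more lipophilic compound), compound 2 gives the higher of the two numbers; the step of a number 0.50 log units higher from compound 1 to compound 2 (beyond the scatter) shows that swapping one two-ring group for another on the amide-type nitrogen moves this assay by a modest amount. Compound 3 `O=C(Nc1ccc(O)cc1)[C@H]1CCCN1C(=O)C1(c2cccc(Cl)c2)CCCC1` carries the change (a group of 7 heavy atoms (6 carbon, 1 oxygen; one six-membered aromatic ring of carbon only) in place of a group of 9 heavy atoms (7 carbon, 2 nitrogen; one five-membered aromatic ring with 1 hetero atom, one six-membered aromatic ring with 1 hetero atom), on an amide-type nitrogen). For the measured compounds named here, no measured step involves the 4-hydroxyphenyl group, so the only guide is the size of the one step seen. A modest downward step is expected, a number 0.50 log units lower from compound 2 to compound 3 (beyond the scatter), since the group entering is smaller. Compound 3 is estimated at 5.4, within 4.9 to 5.9.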

Compound 3, distribution coefficient: 5.5
Beside the measured number, compound 3's estimate is 0.10 log units below it, within the range that was stated.
By their numbers in this assay, from the lowest: compounds 1 and 3 (each within the scatter of the next); then compound 2.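

In this assay, 4-hydroxyphenyl on the amide-type nitrogen gives a number 0.40 log units lower from compound 2 to compound 3 (beyond the scatter) and, set against 1H-indazol-5-yl, gives a number 0.10 log units higher from compound 1 to compound 3 (within the scatter) as its result. At this place, a group with a single aromatic ring therefore cannot be told apart from the two-ring 1H-indazol-5-yl, so the number of rings alone does not set the value across compounds 1, 2 and 3. No available data explain these steps.

Going by these compounds, how a carboxylic acid or an amine on the phenyl ring in place of the hydroxyl would read in this assay remains open. Also open, on these data alone, is whether plain phenyl would stay within the scatter of compound 3.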